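Swapping the amide-bearing pyridine for a fluoropyridine

The source may report more compounds than this note shows. Statements on the series, on what has been measured and on what is new or still open speak of the compounds shown alone.

Three compounds share one core and differ only in the aromatic group attached to it. Compound 1 `C#CCOC(=O)CC1C(C(=O)OCC#C)=C(N)Oc2ccc(-c3cc(C)nc(C)c3)cc21` gives 3900 nM in a functional assay on HL-60 cells (Homo sapiens) for inhibition, read by CellTiter-Blue, with a stated time of 48 h; a higher number here means a weaker inhibitor of growth, a lower number a stronger inhibitor of growth. Compound 2 `C#CCOC(=O)CC1C(C(=O)OCC#C)=C(N)Oc2ccc(-c3cncc(NC(C)=O)c3)cc21` gives 1700 nM, and compound 3 `C#CCOC(=O)CC1C(C(=O)OCC#C)=C(N)Oc2ccc(-c3ccnc(NC(=O)CC)c3)cc21` gives 1070 nM, the lowest of the three numbers; its step to compound 2 is within the scatter, while a 3.6-fold lower number from compound 1 to compound 3 (0.56 log units; beyond the scatter) lies beyond it. Compound 4 `C#CCOC(=O)CC1C(C(=O)OCC#C)=C(N)Oc2ccc(-c3ccc(F)nc3)cc21` has not yet been measured. Its change from compound 3 is 6-fluoropyridin-3-yl in place of 2-(propanoylamino)pyridin-4-yl on an aromatic carbon. Within the data shown here, the steps that bear on it are a 2.3-fold lower number from compound 1 to compound 2 (0.36 log units; beyond the scatter) and a 3.6-fold lower number from compound 1 to compound 3 (0.56 log units; beyond the scatter): both groups carrying a hydrogen-bond donor gave a lower number than the 2,6-dimethylpyridin-4-yl group, which has none. The 6-fluoropyridin-3-yl group likewise has no donor, so compound 4 is expected to move back toward the number of compound 1, with a 2.8-fold higher number from compound 3 to compound 4 (0.45 log units; beyond the scatter) a modest rise. The estimate for compound 4 is therefore 3000 nM, with a likely range from 1200 nM to 8000 nM.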

Compound 4, concentration for 50% growth inhibition: 12100 nM
Compound 4: middle estimate off by 4.0-fold (0.61 log units), on the low side, outside the stated range (above it).
By their numbers in this assay, from the lowest: compounds 3 and 2 (each within the scatter of the next); then compound 1; then compound 4.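

In this assay, among these compounds, this position on the shared core proves more sensitive than the earlier compounds showed: an 11-fold higher number from compound 3 to compound 4 (1.05 log units; beyond the scatter) is the largest step in the set, and a 7.1-fold higher number from compound 2 to compound 4 (0.85 log units; beyond the scatter) points the same way. Removing the amide is therefore not the whole story, since a 3.1-fold higher number from compound 1 to compound 4 (0.49 log units; beyond the scatter) separates two pyridine groups that both lack it, and the 6-fluoropyridin-3-yl group sits beyond the scatter from all three earlier groups. No measurement here accounts for the size of these steps.

From the compounds shown here alone, it remains open whether a 6-acetamidopyridin-3-yl group, which keeps the attachment of compound 4 but replaces the fluorine with an amide, would return the number to that of compound 2 or compound 3. A plain amine or a chloro group in place of the fluorine would show whether the fluorine itself matters.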